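Replacing the Neopentyl Group with Fluorine

A few compounds are considered here, and "the series" means these few. Any claim that something is new, unique, unknown or untested is made for them only; others in the source may bear on it.

Compound 2 `CC(C)c1cccc(C(C)C)c1NC(=O)NCC1(c2ccc(CC(C)(C)C)cc2)CCCC1` stands at the higher of the two numbers measured here: in an assay on microsomes for inhibition of acyl-CoA:cholesterol acyltransferase (Oryctolagus cuniculus) (on this read-out higher numbers stand for weaker inhibition and lower numbers for stronger inhibition), compound 2 gives 159 nM. Going by the values given here, the only other measured compound, compound 1 `CC(C)c1ccc(C2(CNC(=O)Nc3c(C(C)C)cccc3C(C)C)CCCC2)cc1`, gives 48 nM in this assay, and the step of a 3.3-fold higher number from compound 1 to compound 2 (0.52 log units; beyond the scatter) is the one change on record at this position. Compound 3 `CC(C)c1cccc(C(C)C)c1NC(=O)NCC1(c2ccc(F)cc2)CCCC1` is not yet measured; it differs from compound 2 in fluoro in place of neopentyl on an aromatic carbon, with the site described as on an aromatic carbon of a six-membered aromatic ring of carbon only, para to a large group. Among the compounds with values here, the single measured step shows that swapping one group for another at this carbon moved the number by a modest amount, and nothing measured tells how a much smaller group such as fluoro behaves there. Within the data shown here, on that basis compound 3 is expected to land somewhere between the two known numbers, with the step of a 1.6-fold lower number from compound 2 to compound 3 (0.20 log units; within the scatter) as the estimate of the change. For compound 3 the estimated value in this assay is 100 nM, with a range from 30 nM to 350 nM.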

Compound 3, half-maximal inhibitory concentration: 23 nM
Beside the measured number, compound 3's estimate is 4.3-fold (0.64 log units) above it; the measured number lies below the stated range.
By their numbers in this assay, from the lowest: compound 3; then compound 1; then compound 2.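

In this assay, going by these compounds alone, the exchange of neopentyl for fluoro on this aromatic carbon, para to a large group, gives a 6.9-fold lower number from compound 2 to compound 3 (0.84 log units; beyond the scatter) and so runs opposite to the only step known before, which went up on moving from isopropyl to neopentyl. Fluoro also improves on isopropyl, with a 2.1-fold lower number from compound 1 to compound 3 (0.32 log units; beyond the scatter) beyond the scatter, which makes compound 3 the strongest inhibitor of the three and puts the groups in the order fluoro, isopropyl, neopentyl from the lowest number to the highest, so this carbon tolerates a single fluorine atom better than either carbon group shown. Nothing on record explains why the numbers fall in this order and the three compounds establish the order only for these groups on this core.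

The compounds shown leave open how a chlorine atom, a methoxy group, a trifluoromethyl group or an amine would read at this carbon, and whether the number would keep falling with an unsubstituted hydrogen there. They also leave open whether the order of the three groups would hold with a different group in place of the cyclopentane-free parts of the shared core.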